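Cytotoxicity at the hydrazide nitrogen: compound 2 to compound 3

This account rests on a few compounds, and the source may have more. Where it says the series, first, only, none or still open, it means among the compounds named here.

Going by the values given here, compound 2 `Cc1cc(C)cc(S(=O)(=O)c2c(C(=O)NN3CCOC3=O)[nH]c3ccc(Cl)cc23)c1` gives 100 uM in a functional assay on MT4 cells (Homo sapiens) for cytotoxicity, read by MTT assay (on this read-out lower numbers stand for higher toxicity in this test and higher numbers for lower toxicity in this test), the only actual number in this small set. Compound 1 `Cc1cc(C)cc(S(=O)(=O)c2c(C(=O)NCC(=O)NN)[nH]c3ccc(Cl)cc23)c1` gives > 100 uM in this assay, which is a limit of the assay and not a number.

The next change leads to compound 3 `CNNC(=O)c1[nH]c2ccc(Cl)cc2c1S(=O)(=O)c1cc(C)cc(C)c1`: methylamino in place of 2-oxo-1,3-oxazolidin-3-yl on an amide-type nitrogen, (methylamino in place of 2-oxo-1,3-oxazolidin-3-yl on an amide-type nitrogen).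

Among the compounds with values here, one measured step bears on this nitrogen: a number no higher from compound 1 to compound 2 (the limit leaves the size open), with 2-oxo-1,3-oxazolidin-3-yl in place of (aminocarbamoyl)methyl. On these data alone, its size stays open, since the limit of > 100 uM in this assay, at which 1 of the 2 values shown sits, belongs to compound 1. That step therefore sets no scale for the new change.

With compound 2 at 100 uM as the anchor, no shift beyond the usual scatter is expected in this assay, with only a slight lean to a lower number. The expected change is a 1.5-fold lower number from compound 2 to compound 3 (0.19 log units; within the scatter). For compound 3 the estimated value is 65 uM, with an expected range of 20 uM to 200 uM.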

Compound 3, half-maximal toxic concentration: > 100 uM
Compound 3: a limit, no number (the forecaster's own chance of this, stated with the estimate: 40%); at least 1.5-fold (0.18 log units) between middle value and limit.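

In this assay compound 3 gives > 100 uM, which is a limit of the assay and not a number. Methylamino in place of 2-oxo-1,3-oxazolidin-3-yl on the amide-type nitrogen gives a number no lower from compound 2 to compound 3 (the limit leaves the size open), so removing the five-membered ring leaves the read-out at a limit, as with the (aminocarbamoyl)methyl group of compound 1, and the series now has an open-chain group of only 2 heavy atoms on this nitrogen without a lower number. The size of this step and the comparison of compound 1 with compound 3 cannot be read, because the values rest mostly at one ceiling: the limit of > 100 uM in this assay, at which 2 of the 3 values shown sit.

Compound 2 remains the only compound with an actual number, 100 uM, so the compounds shown give no scale for changes on this nitrogen in this assay. On these data alone, whether a larger group here, such as a benzyl group, a longer alkyl chain or a chain ending in a carboxylic acid, would bring the number clearly down remains open, as does the reading of any of these steps at concentrations past the limit.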